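A few compounds are considered here, and "the series" means these few. Any claim that something is new, unique, unknown or untested is made for them only; others in the source may bear on it.

Working notes on the fluoro-indanylidene acetamide series. The single read-out is a functional assay on the whole organism with Mus musculus as the target; on this read-out lower numbers stand for an effect already at smaller amounts and higher numbers for an effect only at larger amounts of compound. Compound 1 `NC(=O)/C=C1\CCc2c(F)cccc21` returns in this assay no number but a limit, > 100 mg/kg. Compound 2 `NC(=O)/C=C1\CCc2c(F)cc(F)cc21` gives 69 mg/kg. Compound 3 `O=C(/C=C1\CCc2c1ccc(F)c2F)NC1CC1` gives 62 mg/kg; its core differs from that of compound 2 in a way not broken down here, and the two numbers sit within the scatter of each other.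

The change from compound 2 to compound 1 is hydrogen in place of fluoro on an aromatic carbon. Its measured step, an at least 1.4-fold higher number from compound 2 to compound 1 (0.16 log units; that floor lies within the scatter), is bounded only because of the limit of > 100 mg/kg in this assay, at which 1 of the 3 values shown sits.

Compound 4 `O=C(/C=C1\CCc2cc(F)ccc21)NC1CC1` differs from compound 3 by hydrogen in place of fluoro on an aromatic carbon. This is the same kind of change as from compound 2 to compound 1, but the surroundings differ: here the carbon is ortho to a fluoro group, ortho to a fused ring and meta to a fused ring, whereas there it was meta to a fluoro group, meta to a fused ring and para to a fused ring.

In this assay the expected step is a 1.8-fold higher number from compound 3 to compound 4 (0.25 log units; within the scatter), resting on the measured step of an at least 1.4-fold higher number from compound 2 to compound 1 (0.16 log units; that floor lies within the scatter). Compound 4 is estimated at 110 mg/kg, between 55 mg/kg and 250 mg/kg, with a real chance that only a limit is returned.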

Compound 4, dose for half-maximal effect: 81 mg/kg
Estimate against measurement, compound 4: 1.4-fold (0.13 log units) above; the range from low to high includes it.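

In this assay, hydrogen in place of fluoro on an aromatic carbon gives a 1.3-fold higher number from compound 3 to compound 4 (0.12 log units; within the scatter), and the comparison with the earlier case reads: the same change on two cores in this assay, an at least 1.4-fold higher number (0.16 log units; that floor lies within the scatter) from compound 2 to compound 1 and a 1.3-fold higher number (0.12 log units; within the scatter) from compound 3 to compound 4; the limit leaves it open whether they differ. The new step lies within the scatter, so it establishes no clear effect of the change on the core of compound 3, although nothing in it conflicts with the earlier result. Whether the size of the step carries from one core to another stays unsettled, as its size on the core of compound 1 is bounded only on one side for this reason: the limit of > 100 mg/kg in this assay, at which 1 of the 4 values shown sits.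

The compounds shown leave open how a chloro or methoxy group would read in place of fluoro on that aromatic carbon. Also open, going by these compounds, is what a longer chain or an amine on the amide nitrogen would give in this assay, and whether the fluoro to hydrogen change would then read the same way.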